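From a Methoxyphenyl Amide to a Methylbenzyl Amide

This account rests on a few compounds, and the source may have more. Where it says the series, first, only, none or still open, it means among the compounds named here.

Compound 2 `COc1ccc(NC(=O)/C=C/c2coc3cc(OC)ccc3c2=O)cc1` carries a 4-methoxyphenyl on an amide-type nitrogen attached to the shared core. In a functional assay on Huh-7 cells (Homo sapiens) for inhibition, read by MTT assay, with a stated time of 48 h (on this read-out higher numbers stand for weaker inhibition and lower numbers for stronger inhibition), compound 2 reaches only a limit, > 100000 nM, so no number is available for it. Compound 1 `COc1ccc2c(=O)c(/C=C/C(=O)Nc3ccccc3Cl)coc2c1` differs from compound 2 at that same nitrogen, and in this assay compound 1 gives 58400 nM. Among the measured compounds shown here, the one measured step, an at least 1.7-fold higher number from compound 1 to compound 2 (0.23 log units; that floor lies within the scatter), runs into the limit of > 100000 nM in this assay, at which 1 of the 2 values shown sits, and says nothing directly about the change now at hand. Compound 3 `COc1ccc2c(=O)c(/C=C/C(=O)NCc3ccc(C)cc3)coc2c1` is the next compound: 4-methylbenzyl in place of 4-methoxyphenyl on an amide-type nitrogen. For the measured compounds named here, no measured step covers this replacement, and the starting point, compound 2, is known only as a limit. Compound 3 is therefore expected to stay weak, with an at least 1.2-fold lower number from compound 2 to compound 3 (0.09 log units; that floor lies within the scatter) read against that limit. The estimate for compound 3 in this assay is 80000 nM, with a range from 25000 nM to 250000 nM.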

Compound 3, half-maximal inhibitory concentration: 14300 nM
Compound 3: middle estimate off by 5.6-fold (0.75 log units), on the high side, outside the stated range (below it).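

Among the compounds shown here, this nitrogen is the first place where a replacement gives a change beyond the scatter. In this assay, 4-methylbenzyl in place of 4-methoxyphenyl gives an at least 6.9-fold lower number from compound 2 to compound 3 (0.84 log units; beyond the scatter), and 4-methylbenzyl in place of 2-chlorophenyl gives a 4.1-fold lower number from compound 1 to compound 3 (0.61 log units; beyond the scatter). Compound 2 is known only as a limit, so the first step is a floor and the real change could be larger: the limit of > 100000 nM in this assay, at which 1 of the 3 values shown sits.

Each replacement changes both the substituent on the ring and the way the ring is attached to the nitrogen, so these compounds cannot show which of the two matters. On these data alone, a 4-methoxybenzyl on the same nitrogen would separate those two changes, and how a longer chain such as 2-phenylethyl would read there remains open.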